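The compounds below may be only part of what the source reports. "The series", "measured", "known", "first", "only" and "open" are said of these compounds alone.

Series notes. Compounds 1, 2 and 3 share one core and differ only in the aryl group on the carbonyl carbon: compound 1 `O=C(NC(=S)N1CCc2c(OCCCCCOc3ccc(Cl)cc3)cccc21)c1cccc([N+](=O)[O-])c1`, compound 2 `O=C(NC(=S)N1CCc2c(OCCCCCOc3ccc(Cl)cc3)cccc21)c1ccc([N+](=O)[O-])cc1`, compound 3 `O=C(NC(=S)N1CCc2c(OCCCCCOc3ccc(Cl)cc3)cccc21)c1ccoc1`. In an ADME assay on Huh-7 cells (Homo sapiens) for cytotoxicity (a higher number here means that more compound is tolerated, a lower number that less compound is tolerated), compound 1 gives 12100 nM, compound 2 gives 13600 nM and compound 3 gives 20100 nM. The steps are a 1.1-fold higher number from compound 1 to compound 2 (0.05 log units; within the scatter), a 1.7-fold higher number from compound 1 to compound 3 (0.22 log units; within the scatter) and a 1.5-fold higher number from compound 2 to compound 3 (0.17 log units; within the scatter), so compound 3 stands together with compounds 1 and 2 in this assay, all within the scatter. Compound 4 `O=C(NC(=S)N1CCc2c(OCCCCCOc3ccc(Cl)cc3)cccc21)c1cccnc1` carries pyridin-3-yl in place of furan-3-yl on a carbonyl carbon. The three measured exchanges at this carbonyl carbon bear on it and none moved this assay beyond the scatter, so no step beyond the scatter is expected: a 1.1-fold lower number from compound 3 to compound 4 (0.05 log units; within the scatter). Compound 4 is therefore estimated at 18000 nM, between 9000 nM and 36000 nM.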

Compound 4, half-maximal cytotoxic concentration: 11100 nM
Compound 4: middle estimate off by 1.6-fold (0.21 log units), on the high side; measured number inside the range.
By their numbers in this assay, from the lowest: compounds 4, 1, 2 and 3 (each within the scatter of the next).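

In this assay, pyridin-3-yl on the carbonyl carbon stays within the scatter of all three earlier groups, with a 1.8-fold lower number from compound 3 to compound 4 (0.26 log units; within the scatter) and a 1.2-fold lower number from compound 2 to compound 4 (0.09 log units; within the scatter) and a 1.1-fold lower number from compound 1 to compound 4 (0.04 log units; within the scatter). This position therefore also accepts a six-membered aromatic ring with one ring nitrogen and no nitro group, without a step beyond the scatter. No measured data bear on these results. Open, from the compounds shown here alone, is whether a saturated piperidine ring in place of the aromatic ring, or an amine or a carboxylic acid on it, would move this assay beyond the scatter.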